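Swapping thiophen-3-yl for 1-benzofuran-2-yl among assay limits

This account rests on a few compounds, and the source may have more. Where it says the series, first, only, none or still open, it means among the compounds named here.

Within the data shown here, compound 3 `Cc1nc(N)c2c(-c3ccsc3)cn([C@@H]3O[C@H](CO)[C@@H](O)[C@H]3O)c2n1` sits at the inactive end of the numbers so far. In a functional assay on HL-60 cells (Homo sapiens) for antiproliferative activity, read by XTT assay, with a stated time of 72 h (a higher number here means a weaker inhibitor, a lower number a stronger inhibitor), compound 3 gives > 20000 nM, which is a limit and not a number. Compound 2 `Cc1nc(N)c2c(-c3ccoc3)cn([C@@H]3O[C@H](CO)[C@@H](O)[C@H]3O)c2n1`, carrying furan-3-yl in the same place, gives > 20000 nM, also a limit. Together these two compounds make up (the limit of > 20000 nM in this assay, at which 2 of the 3 values shown sit).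

The next compound, compound 4 `Cc1nc(N)c2c(-c3cc4ccccc4o3)cn([C@@H]3O[C@H](CO)[C@@H](O)[C@H]3O)c2n1`, has 1-benzofuran-2-yl in place of thiophen-3-yl on an aromatic carbon.

Among the measured compounds shown here, only one measured step bears directly on this change, and it concerns a different swap at the same place: a step that the two limits leave unreadable from compound 2 to compound 3. It therefore gives no size to carry over. Compound 1 `Nc1nc(N)c2c(-c3cc4ccccc4o3)cn([C@@H]3O[C@H](CO)[C@@H](O)[C@H]3O)c2n1` offers the closest clue, since it already bears 1-benzofuran-2-yl, though on a core that is not identical. In this assay compound 1 gives > 15000 nM, again a limit. With no true number anywhere in the set, there is no evidence for a gain in strength, and compound 4 will most likely also be reported only as a limit.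

The expected size of the change is a number no higher from compound 3 to compound 4 (the limit leaves the size open), with no clear move in either direction. The estimate for compound 4 is 20000 nM, with an expected range from 8000 nM to 50000 nM.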

Compound 4, half-maximal inhibitory concentration: > 20000 nM
Compound 4 was reported as a limit; the forecaster's own chance of this, stated with the estimate: 80%; the middle value lies on the limit itself.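

In this assay compound 4 gives > 20000 nM, which is a limit and not a number. Compound 1, compound 2 and compound 3 also stand at limits, and the steps from them to compound 4 cannot be read. The compounds shown leave open how strong any of them truly is and whether these swaps change strength at all.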